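The source may hold more compounds than are shown below. What is called first, only, known or untested is meant among the compounds shown, and "the series" means these compounds.

Of the compounds shown here, three built on one shared core have been measured in an assay on cells for displacement of a labelled ligand from Glucagon receptor (Homo sapiens), in the presence of a further agent that is not named here; a lower number here means a stronger inhibitor, a higher number a weaker inhibitor. Compound 1 `CCCC(Oc1ccc(-n2cc(Cl)cn2)cc1)c1ccc(C(=O)NCCC(=O)O)cc1` gives 1100 nM, compound 2 `CCCC(Oc1ccc(-n2cc(C(F)(F)F)cn2)cc1)c1ccc(C(=O)NCCC(=O)O)cc1` gives 890 nM, and compound 3 `CCCC(Oc1ccc(-n2cc3c(n2)CCCC3)cc1)c1ccc(C(=O)NCCC(=O)O)cc1` gives 690 nM. Compound 3 carries the lowest of the three numbers, yet the steps of a 1.6-fold lower number from compound 1 to compound 3 (0.20 log units; within the scatter) and a 1.3-fold lower number from compound 2 to compound 3 (0.11 log units; within the scatter) both lie within the scatter, so the three cannot really be told apart. Compound 4 `CCCC(Oc1ccc(-n2cc(OC)cn2)cc1)c1ccc(C(=O)NCCC(=O)O)cc1` differs from compound 3 by a group of 7 heavy atoms (4 carbon, 2 nitrogen, 1 oxygen; one five-membered aromatic ring with 2 hetero atoms) in place of a group of 9 heavy atoms (7 carbon, 2 nitrogen; one five-membered aromatic ring with 2 hetero atoms, one six-membered non-aromatic ring of carbon only), on an aromatic carbon. The two measured steps that swap the group at this same place were both within the scatter, so nothing beyond the scatter is expected in this assay here either. The expected step is a 1.3-fold higher number from compound 3 to compound 4 (0.12 log units; within the scatter). Compound 4 is therefore estimated at 900 nM, with a range from 450 nM to 1800 nM.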

Compound 4, inhibition constant: 4400 nM
Beside the measured number, compound 4's estimate is 4.9-fold (0.69 log units) below it; the measured number lies above the stated range.
By their numbers in this assay, from the lowest: compounds 3, 2 and 1 (each within the scatter of the next); then compound 4.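

Until now, changing the group at this place on an aromatic carbon had moved nothing beyond the scatter, but 4-methoxy-1H-pyrazol-1-yl does so in this assay against all three earlier groups (a 6.4-fold higher number from compound 3 to compound 4 (0.80 log units; beyond the scatter); a 4.9-fold higher number from compound 2 to compound 4 (0.69 log units; beyond the scatter); a 4.0-fold higher number from compound 1 to compound 4 (0.60 log units; beyond the scatter)). This place therefore responds to what it carries, and methoxy stands apart from chloro, trifluoromethyl and the group of compound 3. No evidence is available that explains this difference. As far as these compounds go, whether the rise follows the oxygen or methoxy as a whole stays open: a methyl, an ethoxy or a hydroxy group here could separate the two.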